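Swapping 3,4-dimethoxyphenyl for 2,4-difluorophenyl

This account rests on a few compounds, and the source may have more. Where it says the series, first, only, none or still open, it means among the compounds named here.

In a functional assay on ECa-109 cells (Homo sapiens) for cytotoxicity, read by MTT assay, with a stated time of 72 h (on this read-out higher numbers stand for weaker inhibition and lower numbers for stronger inhibition), compound 1 `O=C1C(=Cc2ccc(O)cc2)C(=O)N(c2ccc(Cl)cc2)N1c1ccc(Cl)cc1` gives 34200 nM. Compound 2 `COc1ccc(C=C2C(=O)N(c3ccc(Cl)cc3)N(c3ccc(Cl)cc3)C2=O)cc1OC` is recorded as > 128000 nM, which is a limit of the assay and not a number. Compound 2 therefore has no measured value from which to count a step, only a limit.

Among the measured compounds shown here, the one measured step, an at least 3.7-fold higher number from compound 1 to compound 2 (0.57 log units; beyond the scatter), lies beyond the scatter. It comes with 3,4-dimethoxyphenyl in place of 4-hydroxyphenyl on a double-bonded chain carbon bound to a double-bonded ring carbon.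

Compound 3 `O=C1C(=Cc2ccc(F)cc2F)C(=O)N(c2ccc(Cl)cc2)N1c1ccc(Cl)cc1` keeps the shared core and changes the same place: 2,4-difluorophenyl in place of 3,4-dimethoxyphenyl on a double-bonded chain carbon bound to a double-bonded ring carbon. The 3,4-dimethoxyphenyl group of that measured step leaves again, but 4-hydroxyphenyl does not return, so the step bears on this change only indirectly. A move to a lower number in this assay is therefore expected, of modest size, although compound 3 could also stay at the limit.

An estimated step of an at least 1.8-fold lower number from compound 2 to compound 3 (0.26 log units; that floor lies within the scatter) is expected. For compound 3 the expected value is 70000 nM, with an estimated range of 20000 nM to 128000 nM.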

Compound 3, half-maximal inhibitory concentration: 13100 nM
Beside the measured number, compound 3's estimate is 5.3-fold (0.73 log units) above it, outside the stated range (below it).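

In this assay, the place on a double-bonded chain carbon bound to a double-bonded ring carbon now proves able to move the number down as well as up, with 2,4-difluorophenyl in place of 3,4-dimethoxyphenyl giving an at least 9.7-fold lower number from compound 2 to compound 3 (0.98 log units; beyond the scatter) as the new step. The same group also improves on 4-hydroxyphenyl, with a 2.6-fold lower number from compound 1 to compound 3 (0.42 log units; beyond the scatter) for that exchange, which makes compound 3 the strongest of the three compounds here and shows that a hydroxyl group is not needed at this place for a measurable effect in this assay. Compound 2 is held at a limit and not a number, so the step from it gives only a floor on the size of the change: the limit of > 128000 nM in this assay, at which 1 of the 3 values shown sits.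

With only three groups at this place, the compounds shown do not say whether the two fluorine atoms act together or whether a single fluorine, a chlorine, an amine or a plain phenyl would serve as well. They also leave open what lies behind the lower number, and how far it holds when the rest of the shared core is changed.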